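Swapping chloro for methoxy in a three-compound series

This account rests on a few compounds, and the source may have more. Where it says the series, first, only, none or still open, it means among the compounds named here.

Measured so far in a functional assay on HeLa cells (Homo sapiens) for antiproliferative activity, read by MTT assay, with a stated time of 72 h; on this read-out lower numbers stand for stronger inhibition and higher numbers for weaker inhibition:
- compound 1 `O=C1COc2ccc(-c3cnc(Cl)c(NS(=O)(=O)c4ccc(F)cc4)c3)cc2N1C1CCCCC1` gives 14300 nM
- compound 2 `COc1ccc(N2C(=O)COc3ccc(-c4cnc(Cl)c(NS(=O)(=O)c5ccc(F)cc5)c4)cc32)cc1` gives 8320 nM
- compound 3 `O=C1COc2ccc(-c3cnc(Cl)c(NS(=O)(=O)c4ccc(F)cc4)c3)cc2N1` gives 15600 nM

Compound 2 does not stand apart from the other two, since a 1.7-fold lower number from compound 1 to compound 2 (0.24 log units; within the scatter) and a 1.9-fold higher number from compound 2 to compound 3 (0.27 log units; within the scatter) are the two steps that reach it. The next compound, compound 4 `COc1ccc(N2C(=O)COc3ccc(-c4cnc(OC)c(NS(=O)(=O)c5ccc(F)cc5)c4)cc32)cc1`, keeps all of compound 2 except one group: methoxy in place of chloro on an aromatic carbon. In words, methoxy takes the place of chloro on an aromatic carbon, next to the ring nitrogen and ortho to a ((4-fluorophenyl)sulfonyl)amino group.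

All three measured steps change the group on an amide-type nitrogen in a ring, and a 1.1-fold higher number from compound 1 to compound 3 (0.04 log units; within the scatter) is just as small. Among these three compounds, then, that group made no difference beyond the scatter. None of the steps touches the chloro group, so the data offer no direct guide to this change, and the range must stay wide. Starting from compound 2 at 8320 nM, a modest move towards a lower number is expected, though this is a loose judgement. The expected change is a 2.4-fold lower number from compound 2 to compound 4 (0.38 log units; beyond the scatter) in this assay. For compound 4 the estimated value is 3500 nM, with an expected range from 700 nM to 12000 nM.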

Compound 4, half-maximal inhibitory concentration: 1220 nM
Beside the measured number, compound 4's estimate is 2.9-fold (0.46 log units) above it; the range from low to high includes it.
By their numbers in this assay, from the lowest: compound 4; then compounds 2, 1 and 3 (each within the scatter of the next).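

In this assay the aromatic carbon next to the ring nitrogen proves to be a sensitive position: methoxy in place of chloro gives a 6.8-fold lower number from compound 2 to compound 4 (0.83 log units; beyond the scatter) and this is the only step shown that lies beyond the scatter. The three earlier steps all changed the group on the amide-type nitrogen and stayed within the scatter, so they gave no sign that any part of these molecules could shift the number this far. The structures show only that methoxy brings a hydrogen-bond acceptor where chloro has none, and no measurement shown links that difference, or any other, to the size of this step.

A single swap cannot show whether methoxy itself matters or whether other replacements for chloro, such as ethoxy, an amine or plain hydrogen, would serve as well. As far as these compounds go, it also remains open whether the same swap would lower the number to a similar extent with the cyclohexyl group of compound 1 or the hydrogen of compound 3 on the amide-type nitrogen.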